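Working notes: side chain on the saturated carbon oxygen

The compounds below may be only part of what the source reports. "The series", "measured", "known", "first", "only" and "open" are said of these compounds alone.

- Compound 1 `CC(C)=CC[C@@H](OC(=O)CCO)C1=CC(=O)c2c(O)ccc(O)c2C1=O` gives 67600 nM in a functional assay on HeLa cells (Homo sapiens) for cytotoxicity, read by MTT assay (on this read-out lower numbers stand for stronger inhibition and higher numbers for weaker inhibition), as measured
- Compound 2 `COC(C)CO[C@H](CC=C(C)C)C1=CC(=O)c2c(O)ccc(O)c2C1=O` gives 53400 nM in this assay as measured

Among the measured compounds shown here, compound 2 cannot be separated from compound 1 on these numbers, since the only measured step, a 1.3-fold lower number from compound 1 to compound 2 (0.10 log units; within the scatter), lies within the scatter. Compound 3 `CC(C)=CC[C@@H](OC[C@@H](C)O)C1=CC(=O)c2c(O)ccc(O)c2C1=O` is next in line. Its difference from compound 2 is 1-hydroxyethyl in place of 1-methoxyethyl on a saturated chain carbon bound to an oxygen on a saturated carbon, or 2-methoxypropyl to 2-hydroxypropyl when cut one bond further out.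

For the measured compounds named here, no measured step isolates this exchange. The nearest evidence is a 1.3-fold lower number from compound 1 to compound 2 (0.10 log units; within the scatter), which replaced the whole group on the same oxygen and still moved the read-out by no more than the scatter. That single step is thin support, but it gives no reason to expect a large shift in this assay here. The expected change is a 1.0-fold higher number from compound 2 to compound 3 (0.01 log units; within the scatter), which means no step beyond the scatter. Compound 3 is estimated at 55000 nM with an expected range from 25000 nM to 110000 nM in this series.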

Compound 3, half-maximal inhibitory concentration: 22500 nM
For compound 3 the middle estimate is 2.4-fold (0.39 log units) above the measured one; the whole stated range lies above it.
By their numbers in this assay, from the lowest: compound 3; then compounds 2 and 1 (each within the scatter of the next).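

The position is not silent in this assay: the exchange of 1-methoxyethyl for 1-hydroxyethyl on a saturated chain carbon bound to an oxygen on a saturated carbon gives a modest step (a 2.4-fold lower number from compound 2 to compound 3 (0.38 log units; beyond the scatter)), although the larger replacement of the whole group on that oxygen stayed within the scatter. Compound 3 also separates from compound 1 (a 3.0-fold lower number from compound 1 to compound 3 (0.48 log units; beyond the scatter)), so a hydroxyl at the end of the side chain is not enough by itself, as compound 1 carries one and remains within the scatter of compound 2, which has none. Nothing measured on these compounds gives a reason for either step.

The exchange from compound 2 to compound 3 also brings in a defined stereocentre. The data do not separate the free hydroxyl from that configuration in this step, and the opposite configuration of the 2-hydroxypropyl group is not among the compounds shown. Also open, as far as these compounds go, is how a primary amine in place of that hydroxyl, or a longer chain such as 2-hydroxybutyl, would read in this assay on the same oxygen.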